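The compounds below may be only part of what the source reports. "The series", "measured", "known", "first", "only" and "open" are said of these compounds alone.

Measured so far:
- compound 1, `Cc1ccc(NC(=S)OCCNC(=O)C(C)(C)Oc2ccc(Cl)cc2)cc1`: 0.0167 h
- compound 2, `CC(C)(Oc1ccc(Cl)cc1)C(=O)Oc1ccc(-c2cc(=S)ss2)cc1`: 0.07 h

Both compounds were examined in an ADME assay for pharmacokinetics, in phosphate buffer, tested at 60 uM; on this read-out lower numbers stand for a shorter-lived compound and higher numbers for a longer-lived compound. Compound 1 gives 0.0167 h, and compound 2 gives 0.07 h. Within the data shown here, compound 1 stands lowest of the two numbers; compound 2 is its only neighbour and lies beyond the usual scatter, so the two are genuinely apart, though with only two compounds nothing more general can be drawn from that gap.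

The next compound to be considered is compound 3, `CC(C)(Oc1ccc(Cl)cc1)C(=O)NCCOC(=S)Nc1ccccc1`. It differs from compound 1 in one place only: hydrogen in place of methyl on an aromatic carbon. The methyl sits on a six-membered aromatic ring of carbon only, para to a large group; in the larger reading, 4-methylphenyl becomes phenyl and (4-methylphenyl)amino becomes anilino. The rest of the molecule is untouched.

Among the measured compounds shown here, no pair of measured compounds shows what this particular change does, so the expectation rests on the smallness of the change and on compound 1 alone, whose value of 0.0167 h is the anchor. Compound 3 is expected to show a step of a 1.1-fold higher number from compound 1 to compound 3 (0.03 log units; within the scatter), which is none beyond the scatter. Compound 3 is therefore estimated at 0.018 h, with a likely range from 0.008 h to 0.045 h.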

Compound 3, half-life: 0.0233 h
Beside the measured number, compound 3's estimate is 1.3-fold (0.11 log units) below it; the measured number falls inside the stated range.
By their numbers in this assay, from the lowest: compounds 1 and 3 (each within the scatter of the next); then compound 2.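

In this assay, replacing the methyl on this aromatic carbon with hydrogen, so that 4-methylphenyl becomes phenyl, gives a 1.4-fold higher number from compound 1 to compound 3 (0.14 log units; within the scatter). Among these compounds, this is the first direct look at this position, which the earlier comparison between two quite different structures could not give, and it shows that this single carbon and its hydrogens can go without a change that stands clear of the usual variation between repeated measurements. For this one pair, then, the methyl is not required to give a half-life of this order, and the two compounds must be treated as equal on this read-out, although nothing measured here explains the result.

Going by these compounds, what remains open is whether this position stays as insensitive when it carries something different from a methyl, such as a chlorine atom, a methoxy group, an amine or a carboxylic acid, since a swap between methyl and hydrogen is among the smallest that can be made. The compounds shown also leave open whether a longer chain at this spot, or a methyl placed elsewhere on the same ring, would move the half-life beyond the scatter.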